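A few compounds are considered here, and "the series" means these few. Any claim that something is new, unique, unknown or untested is made for them only; others in the source may bear on it.

Of the compounds shown here, three share one core and have been measured in a functional assay on MDA-MB-231 cells (Homo sapiens) for cytotoxicity, read by MTT assay, with a stated time of 72 h; a lower number here means a stronger inhibitor, a higher number a weaker inhibitor. Compound 1 `CN(C)CCCNc1nc(-c2ccc(NC(=O)Nc3ccccc3Cl)cc2)nc2ccsc12` gives 590 nM in this assay. Compound 2 `CN(C)CCNc1nc(-c2ccc(NC(=O)Nc3ccc(F)cc3)cc2)nc2ccsc12` gives 540 nM in this assay. Compound 3 `CCN(CC)CCCNc1nc(-c2ccc(NC(=O)Nc3ccc(F)cc3)cc2)nc2ccsc12` gives 530 nM in this assay. Compound 3 carries the lowest of the three numbers, yet the step of a 1.0-fold lower number from compound 2 to compound 3 (0.01 log units; within the scatter) is within the scatter, and the gap to compound 1 is within the scatter as well, so no order among the three can be claimed.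

Compound 4 `CCN(CC)CCCNc1nc(-c2ccc(NC(=O)Nc3ccccc3Cl)cc2)nc2ccsc12` differs from compound 3 in one place: 2-chlorophenyl in place of 4-fluorophenyl on an amide-type nitrogen. For the measured compounds named here, no single-place step between measured compounds bears on this change. Going by the values given here, the only hint comes from compound 1 and compound 2, which differ in the same aryl group but also in the chain bearing the dimethylamino group, and whose values in this assay lie within the scatter of each other. On that basis no step beyond the scatter is expected from compound 3 to compound 4 in this assay, so the expected step is a 1.1-fold higher number from compound 3 to compound 4 (0.02 log units; within the scatter). Compound 4 is therefore expected to give about 560 nM in this assay, with a likely range from 300 nM to 1100 nM.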

Compound 4, half-maximal inhibitory concentration: 500 nM
For compound 4 the middle estimate is 1.1-fold (0.05 log units) above the measured one; the range from low to high includes it.
By their numbers in this assay, from the lowest: compounds 4, 3, 2 and 1 (each within the scatter of the next).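

In this assay, for the compounds shown here, the step of a 1.1-fold lower number from compound 3 to compound 4 (0.03 log units; within the scatter) is the first direct reading of 2-chlorophenyl in place of 4-fluorophenyl on an amide-type nitrogen, and it shows that with the diethylamino chain held constant, these two aryl groups cannot be told apart. The step of a 1.2-fold lower number from compound 1 to compound 4 (0.07 log units; within the scatter) adds a direct reading of diethylamino in place of dimethylamino with the 2-chlorophenyl group held constant, and this step also lies within the scatter, so neither single change has yet produced a step beyond it. No measurement at hand offers an explanation for either result.

The change from 4-fluorophenyl to 2-chlorophenyl alters the halogen and its place on the ring together, and the compounds shown leave open how 2-fluorophenyl or 4-chlorophenyl would read on this nitrogen. They also leave open whether a more different group, such as a carboxylic acid on the phenyl ring or a morpholine in place of diethylamino, would give a step beyond the scatter.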